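From Propoxy to Sec-Butoxy on a Shared Core

The compounds below may be only part of what the source reports. "The series", "measured", "known", "first", "only" and "open" are said of these compounds alone.

Compound 1 `Nc1ccccc1-c1ncc(C(=O)O)c(=O)[nH]1`: 50 mg/kg
Compound 2 `COc1ccccc1-c1ncc(C(=O)O)c(=O)[nH]1`: 10 mg/kg
Compound 3 `CCCOc1ccccc1-c1ncc(C(=O)O)c(=O)[nH]1`: 0.9 mg/kg

All three numbers come from a functional assay on the whole organism (strain Sprague-Dawley) for inhibition, with Rattus norvegicus as the target, with a stated time of 10 min; a lower number here means that less compound is needed, a higher number that more compound is needed for the effect. Among them, compound 3 stands lowest at 0.9 mg/kg, so the least compound is needed for the effect. The next compound, compound 4 `CCC(C)Oc1ccccc1-c1ncc(C(=O)O)c(=O)[nH]1`, turns propoxy into sec-butoxy, and the difference counts as methyl in place of hydrogen on a saturated chain carbon bound to an oxygen on an aromatic ring and a saturated chain carbon. The closest measured precedent added ethyl in place of hydrogen on the same kind of chain carbon, and it was a large step: an 11-fold lower number from compound 2 to compound 3 (1.05 log units; beyond the scatter). The steps of a 5.0-fold lower number from compound 1 to compound 2 (0.70 log units; beyond the scatter) and a 56-fold lower number from compound 1 to compound 3 (1.74 log units; beyond the scatter) replace amino, which is a different change, so they bear on this one less directly. Going by the values given here, the new methyl is a smaller addition than that ethyl, and no measured compound has a branched chain. A step beyond the scatter in this assay is therefore not expected, though a slightly lower number seems likelier than a higher one. The expected step is a 1.3-fold lower number from compound 3 to compound 4 (0.11 log units; within the scatter). For compound 4 the estimated value is 0.7 mg/kg, with an expected range from 0.2 mg/kg to 2.5 mg/kg.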

Compound 4, dose for 50% inhibition: 0.5 mg/kg
Estimate against measurement, compound 4: 1.4-fold (0.15 log units) above; the range from low to high includes it.
By their numbers in this assay, from the lowest: compounds 4 and 3 (each within the scatter of the next); then compound 2; then compound 1.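

In this assay, methyl in place of hydrogen on the saturated chain carbon bound to an oxygen on an aromatic ring and a saturated chain carbon gives a small step (a 1.8-fold lower number from compound 3 to compound 4 (0.26 log units; within the scatter)), so this branched chain and the unbranched propoxy cannot be told apart here. Compound 4 also keeps the large distance from the other two compounds, first against the smaller ether (a 20-fold lower number from compound 2 to compound 4 (1.30 log units; beyond the scatter)) and then against the amino compound (a 100-fold lower number from compound 1 to compound 4 (2.00 log units; beyond the scatter)). No measurement on hand says why the numbers fall as they do.

On these data alone, whether a tert-butoxy group, with still more branching, or a longer chain such as pentyloxy would hold this level remains open. So does the effect of a cyclopentyloxy ring or an amine at the end of the chain.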